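Swapping the halogens on compound 3

This account rests on a few compounds, and the source may have more. Where it says the series, first, only, none or still open, it means among the compounds named here.

Three related compounds share one core and differ only in the aromatic group on a carbonyl carbon. In a functional assay on C8166 cells (Homo sapiens) for cytotoxicity, read by MTT assay (a lower number here means that less compound is tolerated, a higher number that more compound is tolerated), compound 1 `Cc1ccc(C(=O)Nc2cc(Cl)ccc2OCC(=O)Nc2ccc(S(N)(=O)=O)cc2C)cc1C` gives 84100 nM as its value, compound 2 `Cc1cc(C)cc(C(=O)Nc2cc(Cl)ccc2OCC(=O)Nc2ccc(S(N)(=O)=O)cc2C)c1` gives 36500 nM as its value, and compound 3 `Cc1cc(S(N)(=O)=O)ccc1NC(=O)COc1ccc(Cl)cc1NC(=O)c1ccc(Cl)c(Cl)c1` gives 158000 nM as its value. Compound 3 cannot be told apart from its nearest neighbour, since a 1.9-fold higher number from compound 1 to compound 3 (0.27 log units; within the scatter) is no real gap, while a 4.3-fold higher number from compound 2 to compound 3 (0.64 log units; beyond the scatter) is a real but modest one.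

Compound 4 `Cc1cc(S(N)(=O)=O)ccc1NC(=O)COc1ccc(Cl)cc1NC(=O)c1cc(Cl)cc(Br)c1` carries 3-bromo-5-chlorophenyl in place of 3,4-dichlorophenyl on a carbonyl carbon and is otherwise unchanged. Going by the values given here, no measured step shows bromine entering. The closest guide is 3,5-dimethylphenyl in place of 3,4-dimethylphenyl on a carbonyl carbon, which gave a 2.3-fold lower number from compound 1 to compound 2 (0.36 log units; beyond the scatter) as its step. That is a single modest step, so only part of it is carried over. The expected step is a 1.9-fold lower number from compound 3 to compound 4 (0.27 log units; within the scatter) and points downward. In this assay compound 4 is estimated at 85000 nM with a range of 35000 nM to 190000 nM around that figure.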

Compound 4, half-maximal cytotoxic concentration: 114000 nM
Estimate against measurement, compound 4: 1.3-fold (0.13 log units) below; low and high end bracket the measured number.
By their numbers in this assay, from the lowest: compound 2; then compounds 1, 4 and 3 (each within the scatter of the next).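

In this assay, 3-bromo-5-chlorophenyl on the carbonyl carbon cannot be told apart from 3,4-dichlorophenyl (a 1.4-fold lower number from compound 3 to compound 4 (0.14 log units; within the scatter)), so this position takes a bromine and a different halogen arrangement with no readable change. The new compound also sits level with the 3,4-dimethylphenyl compound (a 1.4-fold higher number from compound 1 to compound 4 (0.13 log units; within the scatter)), but it stands clear of the 3,5-dimethylphenyl compound (a 3.1-fold higher number from compound 2 to compound 4 (0.49 log units; beyond the scatter)), which shows that the arrangement shared by 3,5-dimethylphenyl and 3-bromo-5-chlorophenyl does not alone go with the lowest number in this set. Nothing available explains these numbers.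

The compounds shown do not separate the effect of bromine entering from that of the chlorine changing place, as both differ at once between compound 3 and compound 4. As far as these compounds go, it also remains open how this position would respond to an amine or a carboxylic acid on the aromatic ring.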